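This account rests on a few compounds, and the source may have more. Where it says the series, first, only, none or still open, it means among the compounds named here.

Of the compounds shown here, three have been tested in a functional assay on NCI-H1650 cells (Homo sapiens) for cytotoxicity, read by MTT assay, with a stated time of 48 h (on this read-out higher numbers stand for weaker inhibition and lower numbers for stronger inhibition), so far. Compound 1 `CN(C)CCNc1ccnc2cc(OCc3ccc(F)cc3)ccc12` gives 780 nM in this assay. Compound 2 `CC(C)COc1ccc2c(Cl)ccnc2c1` gives 2100 nM, and compound 3 `CCCCOc1ccc2c(Cl)ccnc2c1` gives 2570 nM. Compound 3 therefore stands at the highest number of the three, with compound 2 closest to it and compound 1 furthest away.

The next compound, compound 4 `CCCCCCCCOc1ccc2c(Cl)ccnc2c1`, keeps the core of compound 3 and differs from it in one place: butyl in place of hydrogen on a saturated chain carbon, four bonds along the chain from an oxygen on an aromatic ring. For the measured compounds named here, the only measured step that speaks to this kind of change is the one within the alkyl chain on the ether oxygen, where a 1.2-fold higher number from compound 2 to compound 3 (0.09 log units; within the scatter). That step lengthened the chain by a small amount and left the number essentially where it was. The move to compound 4 lengthens the chain further than any measured pair does, so the expectation rests on that single step alone, and nothing shows what a much longer chain does here.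

On that basis, the step from compound 3 to compound 4 is expected to be a 1.2-fold higher number from compound 3 to compound 4 (0.07 log units; within the scatter), not beyond the scatter in either direction. For compound 4 in this assay the estimated value is 3000 nM, with a range from 1200 nM to 8000 nM.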

Compound 4, half-maximal inhibitory concentration: 3240 nM
Compound 4: middle estimate off by 1.1-fold (0.03 log units), on the low side, and the stated range covers the measured number.
By their numbers in this assay, from the lowest: compound 1; then compounds 2, 3 and 4 (each within the scatter of the next).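

In this assay, butyl in place of hydrogen on a saturated chain carbon, four bonds along the chain from an oxygen on an aromatic ring, gives a 1.3-fold higher number from compound 3 to compound 4 (0.10 log units; within the scatter), so even this addition of four carbons stays within the scatter. For the compounds shown here, until now the only reading on this chain was the smaller change, a 1.2-fold higher number from compound 2 to compound 3 (0.09 log units; within the scatter), and a much larger change now gives the same answer: across compounds 2, 3 and 4, plain alkyl chains of quite different size on this oxygen leave the number where it was, with no step beyond the scatter. Nothing measured here gives a reason for this flat response.

As far as these compounds go, these compounds carry only plain carbon chains on the oxygen, so it remains open whether an amine, a carboxylic acid or a phenyl ring on that chain would leave the number as unchanged, or whether a still longer chain would. Compound 1 differs from the others in more than one place, so the separate contributions of those differences to its number cannot be read from this set.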